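A few compounds are considered here, and "the series" means these few. Any claim that something is new, unique, unknown or untested is made for them only; others in the source may bear on it.

Compound 1 `O=C(Nc1ccccc1)c1c(NO)cc(-c2cccs2)oc1=O`, compound 2 `O=C(Nc1ccc(F)cc1)c1c(NO)cc(-c2cccs2)oc1=O` and compound 3 `Cc1ccccc1NC(=O)c1c(NO)cc(-c2cccs2)oc1=O` share one core and were tested in an ADME assay on Huh-7 cells (Homo sapiens) for cytotoxicity, with a stated time of 3 days; a higher number here means that more compound is tolerated, a lower number that less compound is tolerated. Compound 1 reaches only a limit of the assay, > 20000 nM. Compound 2 likewise gives a limit, > 20000 nM. Compound 3 also sits at a limit, > 20000 nM, and so stands level with the other two as far as the numbers reach. The steps a step that the two limits leave unreadable from compound 1 to compound 2, a step that the two limits leave unreadable from compound 1 to compound 3 and a step that the two limits leave unreadable from compound 2 to compound 3 have no readable size because of the limit of > 20000 nM in this assay, at which 3 of the 3 values shown sit. Compound 4 `COc1ccc(NC(=O)c2c(NO)cc(-c3cccs3)oc2=O)cc1` differs from compound 3 in one place: 4-methoxyphenyl in place of 2-methylphenyl on an amide-type nitrogen. Since every bearing step is unreadable, no step beyond the scatter is expected, a step that the limit leaves unreadable from compound 3 to compound 4. Compound 4 is therefore expected to give 30000 nM, in a range from 12000 nM to 100000 nM.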

Compound 4, half-maximal cytotoxic concentration: > 20000 nM
Compound 4 was reported as a limit; the forecaster's own chance of this, stated with the estimate: 85%; the middle value lies beyond the limit too.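

No step among compound 1, compound 2, compound 3 and compound 4 can be read in this assay, because all four give the same limit: the limit of > 20000 nM in this assay, at which 4 of the 4 values shown sit.

The compounds shown leave open at what concentration any of them becomes cytotoxic, and whether the groups on the amide-type nitrogen make any difference there.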